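Swapping 2-chlorophenyl for 4-methoxyphenyl on the amide

The source may report more compounds than this note shows. Statements on the series, on what has been measured and on what is new or still open speak of the compounds shown alone.

Going by the values given here, in a functional assay on HCT-116 cells (Homo sapiens) for inhibition, read by MTT assay, with a stated time of 2 days (on this read-out higher numbers stand for weaker inhibition of growth and lower numbers for stronger inhibition of growth), compound 1 (`Nc1ccccc1NC(=O)CCCNCC(=O)Nc1cccc(Cl)c1`) gives 11600 nM and compound 2 (`Nc1ccccc1NC(=O)CCCNCC(=O)Nc1ccccc1Cl`) gives 21800 nM, so compound 2 stands within the scatter of its only neighbour. Compound 3 (`COc1ccc(NC(=O)CNCCCC(=O)Nc2ccccc2N)cc1`) carries 4-methoxyphenyl in place of 2-chlorophenyl on an amide-type nitrogen. Among the compounds with values here, the only measured step, a 1.9-fold higher number from compound 1 to compound 2 (0.27 log units; within the scatter), concerns the same amide group but not this exchange, so it offers weak guidance and suggests little movement. The expected change is a 1.4-fold lower number from compound 2 to compound 3 (0.13 log units; within the scatter), with none beyond the scatter foreseen. The estimate for compound 3 is 16000 nM, with an expected range from 6000 nM to 40000 nM.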

Compound 3, concentration for 50% growth inhibition: 8600 nM
Compound 3: the middle estimate sits 1.9-fold (0.27 log units) above what was measured, within the range that was stated.
By their numbers in this assay, from the lowest: compounds 3, 1 and 2 (each within the scatter of the next, the first and the last beyond it).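

In this assay, going by these compounds alone, the group on this amide-type nitrogen can shift the number beyond the scatter: 4-methoxyphenyl in place of 2-chlorophenyl gives a modest change (a 2.5-fold lower number from compound 2 to compound 3 (0.40 log units; beyond the scatter)), the first such step in this set. In place of 3-chlorophenyl, the same group gives a change within the scatter (a 1.3-fold lower number from compound 1 to compound 3 (0.13 log units; within the scatter)), so compound 3 cannot be separated from compound 1. Nothing available here explains either step.

Still open, going by these compounds, is how an amine or a carboxylic acid on this aromatic ring would compare with the methoxy and chlorine groups. A longer chain in the shared core is also untested in these compounds.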